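Trifluoromethyl for Methyl on a Potassium-Channel Activator Series

This account rests on a few compounds, and the source may have more. Where it says the series, first, only, none or still open, it means among the compounds named here.

The measured compounds and their values:
compound 1, `Cc1cc(NC(=O)Cn2nnc(-c3cccnc3)n2)n(C2CCCCC2)n1`: 96%
compound 2, `Cc1cc(NC(=O)Cn2nnc(-c3cccc(Cl)c3)n2)n(C2CCCCC2)n1`: 89%
compound 3, `Cc1cccc(-c2nnn(CC(=O)Nc3cc(C)nn3C3CCCCC3)n2)c1`: 93%

In an assay on HEK293 cells for activation of Kir3.1/Kir3.2 (Homo sapiens), read by thallium flux (on this read-out higher numbers stand for larger maximal responses and lower numbers for smaller maximal responses), compound 1 reaches 96%, compound 2 reaches 89%, and compound 3 reaches 93%. The three compounds share one core and differ only in the aromatic group attached to it. On the numbers shown, compound 3 lies between the other two, yet all three values sit within the scatter of one another: a number 3 percentage points lower from compound 1 to compound 3 (within the scatter) and a number 4 percentage points higher from compound 2 to compound 3 (within the scatter).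

Compound 4, `Cc1cc(NC(=O)Cn2nnc(-c3cccc(C(F)(F)F)c3)n2)n(C2CCCCC2)n1`, has not yet been measured. It differs from compound 3 in one place: trifluoromethyl in place of methyl on an aromatic carbon.

Among the compounds with values here, the steps that bear on this are the exchanges at the same aromatic carbon. From compound 2 to compound 3 the swap of chloro for methyl gave a number 4 percentage points higher from compound 2 to compound 3 (within the scatter), and the exchange of the whole aromatic group gave a number 7 percentage points lower from compound 1 to compound 2 (within the scatter) and a number 3 percentage points lower from compound 1 to compound 3 (within the scatter). None of these moved the maximal response beyond the scatter, so no step beyond the scatter is expected for compound 4 in this assay either, and the expected change is a number 3 percentage points lower from compound 3 to compound 4 (within the scatter). Compound 4 is therefore estimated to reach 90%, in a range from 78% to 100%.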

Compound 4, largest response reached (Emax), in percent of the reference or control that the assay uses: 86%
Compound 4: the middle estimate sits 4 percentage points above what was measured; the range from low to high includes it.
By their numbers in this assay, from the lowest: compounds 4, 2, 3 and 1 (each within the scatter of the next).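

In this assay, the position meta to a large group on the aromatic ring accepts trifluoromethyl, with 4 heavy atoms, in place of methyl, with 1, and the step stays within the scatter (a number 7 percentage points lower from compound 3 to compound 4 (within the scatter)). The same holds when trifluoromethyl replaces chloro at this carbon (a number 3 percentage points lower from compound 2 to compound 4 (within the scatter)) and when 3-(trifluoromethyl)phenyl replaces the whole pyridin-3-yl group (a number 10 percentage points lower from compound 1 to compound 4 (within the scatter)), so this larger substituent adds a further case in which the aromatic group changes without a step beyond the scatter. No outside evidence bears on this result, so the numbers record what happens at this position and offer no explanation.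

The compounds shown leave open whether any group at this aromatic carbon can move the maximal response beyond the scatter, for example an amine, a carboxylic acid or a longer chain such as butyl. They also leave open how changes elsewhere on the shared core would read out, and this read-out gives only the largest response reached, not how much compound is needed to reach it.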